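The source may hold more compounds than are shown below. What is called first, only, known or untested is meant among the compounds shown, and "the series" means these compounds.

In a functional assay on NCI-H460 cells (Homo sapiens) for inhibition, read by MTT assay, with a stated time of 72 h (a lower number here means a stronger inhibitor, a higher number a weaker inhibitor), compound 1 `CCN(CC)CCCn1c(=O)c(=Cc2cc(OC)c(OC)c(OC)c2)s/c1=C1\C(=O)Nc2ccc(C)cc21` gives 2670 nM, the second highest of the three numbers recorded. Compound 2 `CCN(CC)CCCn1c(=O)c(=Cc2ccc(O)cc2)s/c1=C1\C(=O)Nc2ccc(C)cc21` gives 260 nM, and the step of a 10-fold lower number from compound 1 to compound 2 (1.01 log units; beyond the scatter) is large. Compound 3 `CCN(CC)CCCn1c(=O)c(=Cc2ccccc2O)s/c1=C1\C(=O)Nc2ccc(C)cc21` gives 11300 nM; the step of a 4.2-fold higher number from compound 1 to compound 3 (0.63 log units; beyond the scatter) is modest, while the step of a 43-fold higher number from compound 2 to compound 3 (1.64 log units; beyond the scatter) is large. All three measured steps alter only the group on the double-bonded chain carbon bound to an aromatic carbon. Compound 4 `CCN(CC)CCCn1c(=O)c(=Cc2cc(OC)c(OC)c(OC)c2)s/c1=C1\C(=O)Nc2ccc(Cl)cc21` differs from compound 1 by chloro in place of methyl on an aromatic carbon. Among the measured compounds shown here, no measured step touches the fused ring of the shared core, so nothing recorded bears directly on this change, and no shift beyond the scatter is expected in this assay. Compound 4 is therefore estimated at 2200 nM, with a range from 700 nM to 7000 nM, a step of a 1.2-fold lower number from compound 1 to compound 4 (0.08 log units; within the scatter).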

Compound 4, half-maximal inhibitory concentration: 2990 nM
Estimate against measurement, compound 4: 1.4-fold (0.13 log units) below, within the range that was stated.
By their numbers in this assay, from the lowest: compound 2; then compounds 1 and 4 (each within the scatter of the next); then compound 3.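

Among the compounds shown here, replacing methyl with chloro on this aromatic carbon of the fused ring gives a 1.1-fold higher number from compound 1 to compound 4 (0.05 log units; within the scatter) in this assay, the first reading at a position away from the aryl group that had varied so far. Here, with the 3,4,5-trimethoxyphenyl group held fixed, the two substituents cannot be told apart, whereas every earlier change of the aryl group gave a step beyond the scatter. No measurement at hand speaks to why.

From the compounds shown here alone, whether an amine or a carboxylic acid on this carbon would shift the number remains open. So does whether chloro and methyl would also match alongside the 4-hydroxyphenyl group of compound 2.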